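The compounds below may be only part of what the source reports. "The series", "measured", "known", "first", "only" and "open" are said of these compounds alone.

Of the compounds shown here, three built on one shared core have been tested in an ADME assay on Vero cells (Chlorocebus sabaeus) for cytotoxicity, with a stated time of 72 h, tested at 50 ug/mL; on this read-out lower numbers stand for a weaker effect and higher numbers for a stronger effect at the one concentration tested. Compound 1 `N/N=C1\NCCN1c1ccccc1Cl` gives 0%. Compound 2 `Cc1ccc(N2CCN/C2=N\N)cc1` gives 9%, and compound 3 `COc1ccc(N2CCN/C2=N\N)cc1` gives 0%. Compound 3 stands level with compound 1 at the digits shown, and the two together hold the lowest numbers of the three, while compound 2 lies a little higher, a gap that is within the scatter of this kind of measurement. Compound 4 `N/N=C1\NCCN1c1ccccc1` has not yet been measured; it differs from compound 3 in one place, (hydrogen in place of methoxy on an aromatic carbon). Among the compounds with values here, the only measured step that bears on this change is the exchange of methyl for methoxy on an aromatic carbon, which gave a number 9 percentage points lower from compound 2 to compound 3 (within the scatter), a shift within the scatter. Swapping groups on this aromatic carbon has therefore so far left the read-out essentially unmoved, and no step beyond the scatter is expected here either. Compound 4 is thus expected to give about 2%, with a likely range from 0% to 12%, meaning an expected step of a number 2 percentage points higher from compound 3 to compound 4 (within the scatter).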

Compound 4, a percentage reported as inhibition, at one concentration (the size of the read-out at that concentration, not a potency): 0%
Compound 4: middle estimate off by 2 percentage points, on the high side; the measured number falls inside the stated range.
By their numbers in this assay, from the lowest: compounds 1, 3, 4 and 2 (each within the scatter of the next).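

Taking the group away altogether shows more than exchanging one group for another: in this assay hydrogen in place of methoxy gives no change at the digits printed from compound 3 to compound 4 (within the scatter) and hydrogen in place of methyl gives a number 9 percentage points lower from compound 2 to compound 4 (within the scatter) while hydrogen in place of chloro gives no change at the digits printed from compound 1 to compound 4 (within the scatter). The compound with no group on its aromatic ring therefore cannot be told apart from those carrying methoxy, methyl or chloro, so none of these three groups has a visible effect on this read-out at the one concentration tested. Nothing available explains this flat picture.

As far as these compounds go, whether an amine, a carboxylic acid or a longer chain on this aromatic carbon would also leave the read-out unmoved remains open. A single concentration also leaves open how these compounds would behave at other concentrations.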